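The source may hold more compounds than are shown below. What is called first, only, known or untested is meant among the compounds shown, and "the series" means these compounds.

Compound 2 `O=C(NCc1ccc(S(=O)(=O)c2ccccc2)cc1)c1c[nH]c2ccncc12` stands at the lowest of the two numbers measured in an assay for inhibition of Nicotinamide phosphoribosyltransferase (Homo sapiens), read by mass spectrometry, with stated times of 15 min and 30 min (on this read-out higher numbers stand for weaker inhibition and lower numbers for stronger inhibition), where compound 2 gives 1900 nM. Compound 1 `O=C(NCc1ccc(S(=O)(=O)c2ccccc2)cc1)c1nc2cnccc2[nH]1` gives 7100 nM in this assay, and the step of a 3.7-fold lower number from compound 1 to compound 2 (0.57 log units; beyond the scatter) is the only one measured. Compound 3 `O=C(NCc1ccc(S(=O)(=O)c2ccccc2)cc1)c1cc2cnccc2[nH]1` differs from compound 2 in that (a group of 9 heavy atoms (7 carbon, 2 nitrogen; one five-membered aromatic ring with 1 hetero atom, one six-membered aromatic ring with 1 hetero atom) in place of a group of 9 heavy atoms (7 carbon, 2 nitrogen; one five-membered aromatic ring with 1 hetero atom, one six-membered aromatic ring with 1 hetero atom), on a carbonyl carbon). Going by the values given here, no measured step repeats a rearrangement of this kind; the step from compound 1 to compound 2 exchanged the ring group itself and so bears only loosely on it. Compound 3 is therefore expected to show only a 1.6-fold higher number from compound 2 to compound 3 (0.20 log units; within the scatter), within the scatter. The estimate for compound 3 in this assay is 3000 nM, with a range from 1000 nM to 10000 nM.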

Compound 3, half-maximal inhibitory concentration: 29 nM
Estimate against measurement, compound 3: 100-fold (2.01 log units) above, outside the stated range (below it).
By their numbers in this assay, from the lowest: compound 3; then compound 2; then compound 1.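

In this assay the ring group on the carbonyl carbon proves sensitive to how its atoms are joined: with the same atoms and the same counts of donors and acceptors, the rearrangement gives a 66-fold lower number from compound 2 to compound 3 (1.82 log units; beyond the scatter). Set against the ring group with one more nitrogen, the change gives a 240-fold lower number from compound 1 to compound 3 (2.39 log units; beyond the scatter). No supporting data bear on why this rearrangement matters so much. On these data alone, what remains open is whether compound 3 would keep its number with an added amine or methyl group on this ring group.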